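From a 2-Fluorophenyl to a 3-Bromophenyl Group

The source may hold more compounds than are shown below. What is called first, only, known or untested is meant among the compounds shown, and "the series" means these compounds.

Of the compounds shown here, three sharing one core have been tested in a functional assay on the whole organism for inhibition, with Rattus norvegicus as the target; a lower number here means that less compound is needed, a higher number that more compound is needed for the effect. Compound 1, `CC1CC/C(=N\Nc2ccccc2)c2nccc(=O)n21`, gives only a limit of the assay rather than a number, > 100 umol/kg. Compound 2, `CC1CC/C(=N\Nc2ccccc2)c2ncc(C(N)=O)c(=O)n21`, which carries a carbamoyl in place of hydrogen on an aromatic carbon, also reaches only a limit, > 1000 umol/kg. The step that the two limits leave unreadable from compound 1 to compound 2 therefore cannot be read. Compound 3, `CC1CC/C(=N\Nc2ccccc2F)c2ncc(C(=O)O)c(=O)n21`, likewise gives only a limit, > 1000 umol/kg. For the measured compounds named here, all three values thus sit at limits, one at the limit of > 100 umol/kg in this assay, at which 1 of the 3 values shown sits, and two at the limit of > 1000 umol/kg in this assay, at which 2 of the 3 values shown sit, and no measured step has a readable size.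

Compound 4, `CC1CC/C(=N\Nc2cccc(Br)c2)c2ncc(C(=O)O)c(=O)n21`, differs from compound 3 in one place: 3-bromophenyl in place of 2-fluorophenyl on an amine nitrogen. Going by the values given here, no measured step touches the group on the amine nitrogen, so the known data give no direction for this change, and the simplest expectation is that compound 4 stays near the limit found for compound 3. For compound 4 the dose is expected at about 2000 umol/kg, within a range from 500 umol/kg to 10000 umol/kg. The step this estimate means is a step that the limit leaves unreadable from compound 3 to compound 4, which is no change beyond the scatter.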

Compound 4, dose for 50% inhibition: > 320 umol/kg
Compound 4 gave a limit, no number; the forecaster's own chance of this, stated with the estimate: 75%; the middle value does not contradict the limit.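

In this assay compound 3 gives only a limit, > 1000 umol/kg. Compound 4 also gives only a limit, > 320 umol/kg. For the compounds shown here, no step from compound 3 to compound 4 can therefore be read. The compounds shown leave open whether 3-bromophenyl in place of 2-fluorophenyl changes the dose needed at all.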